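This account rests on a few compounds, and the source may have more. Where it says the series, first, only, none or still open, it means among the compounds named here.

Measured compounds:
compound 1 `NNc1nonc1/C(=N/O)Nc1ccc(F)c(Br)c1`, in an assay on HeLa cells for inhibition of Indoleamine 2,3-dioxygenase 1 (Homo sapiens), read by spectrophotometry, with a stated time of 24 h (on this read-out higher numbers stand for an effect only at larger amounts of compound and lower numbers for an effect already at smaller amounts), compound 1 gives 556 nM
compound 2 `O=S1(=O)CC(Nc2nonc2/C(=N/O)Nc2ccc(F)c(Br)c2)C1`, in this assay compound 2 gives 59 nM
compound 3 `N=S1(=O)CC(Nc2nonc2/C(=N/O)Nc2ccc(F)c(Br)c2)C1`, in this assay compound 3 gives 53 nM

Compound 3 gives the lowest of the three numbers in this assay, but its nearest neighbour, compound 2, lies within the scatter of it a 1.1-fold lower number from compound 2 to compound 3 (0.05 log units; within the scatter), so the two cannot be ordered; only compound 1 stands clearly apart a 10-fold lower number from compound 1 to compound 3 (1.02 log units; beyond the scatter). Compound 4 `CCNS(=O)(=O)CCNc1nonc1/C(=N/O)Nc1ccc(F)c(Br)c1` differs from compound 3 in one place: a group of 8 heavy atoms (4 carbon, 1 nitrogen, 2 oxygen, 1 sulfur; no ring) in place of a group of 6 heavy atoms (3 carbon, 1 nitrogen, 1 oxygen, 1 sulfur; one four-membered non-aromatic ring with 1 hetero atom), on a nitrogen on an aromatic ring. Going by the values given here, two measured steps bear on this. Replacing the terminal nitrogen of compound 1 by a four-membered ring bearing a sulfur group gave a 9.4-fold lower number from compound 1 to compound 2 (0.97 log units; beyond the scatter) and a 10-fold lower number from compound 1 to compound 3 (1.02 log units; beyond the scatter), while exchanging one oxygen on that sulfur for nitrogen gave a 1.1-fold lower number from compound 2 to compound 3 (0.05 log units; within the scatter). Among the compounds with values here, no measured step opens the ring into a chain, so that part of the change is untested. Compound 4 is therefore expected to stay near compound 3 in this assay, with a step of a 1.7-fold higher number from compound 3 to compound 4 (0.23 log units; within the scatter) that may reach the edge of the scatter. The estimate for compound 4 is 90 nM, within 30 nM to 300 nM.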

Compound 4, half-maximal effective concentration: 41 nM
Estimate against measurement, compound 4: 2.2-fold (0.34 log units) above; the measured number falls inside the stated range.
By their numbers in this assay, from the lowest: compounds 4, 3 and 2 (each within the scatter of the next); then compound 1.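

In this assay, opening the four-membered ring into the 2-(ethylsulfamoyl)ethyl chain on the nitrogen on an aromatic ring leaves the number within the scatter of both ring compounds (a 1.3-fold lower number from compound 3 to compound 4 (0.11 log units; within the scatter); a 1.4-fold lower number from compound 2 to compound 4 (0.16 log units; within the scatter)). The ring is therefore not required for the gain over compound 1, since the open chain in place of amino keeps that gain beyond the scatter (a 14-fold lower number from compound 1 to compound 4 (1.13 log units; beyond the scatter)). Nothing given here explains why the ring and the chain read alike.

The compounds shown leave open whether the sulfur group itself is needed, as a plain butyl chain or a chain ending in an amine or a carboxylic acid would test that. They also leave open how a longer chain between this nitrogen and the sulfur would read.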